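The source may report more compounds than this note shows. Statements on the series, on what has been measured and on what is new or still open speak of the compounds shown alone.

In a functional assay on KB cells (Homo sapiens) for antiproliferative activity, read by sulforhodamine B assay, with a stated time of 3 days (on this read-out lower numbers stand for an effect already at smaller amounts and higher numbers for an effect only at larger amounts of compound), compound 1 `CCC1=C(O)c2c(oc(-c3ccc(C(C)C)cc3)cc2=O)C(CC)(CC)C1=O` gives 8.13 uM, while compound 2 `CCCCc1ccc(-c2cc(=O)c3c(o2)C(CC)(CC)C(=O)C(CC)=C3O)cc1` gives 111 uM, the higher of the two numbers. Among the measured compounds shown here, compound 2 therefore stands at the top of the measured values, with compound 1 as its only neighbour. Compound 3 `CCC1=C(O)c2c(oc(-c3ccc(CC(C)C)cc3)cc2=O)C(CC)(CC)C1=O` has not yet been measured. It differs from compound 2 by isopropyl in place of propyl on a saturated chain carbon bound to an aromatic carbon, with isopropyl in place of propyl on a saturated chain carbon bound to an aromatic carbon, which can also be read as butyl to isobutyl. For the measured compounds named here, only one measured step bears on this change: the replacement of isopropyl by butyl on an aromatic carbon, a 14-fold higher number from compound 1 to compound 2 (1.14 log units; beyond the scatter), a large step beyond the scatter. That single step concerns the same substituent but is not the same exchange, so it offers a direction only tentatively. With isobutyl as a partial return toward the isopropyl of compound 1, a moderate step is expected in this assay, smaller than the step just described: a 3.7-fold lower number from compound 2 to compound 3 (0.57 log units; beyond the scatter). For compound 3 the estimated value is 30 uM, with an expected range from 9 uM to 100 uM.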

Compound 3, concentration for half-maximal effect: 29.3 uM
Beside the measured number, compound 3's estimate is 1.0-fold (0.01 log units) above it; the measured number falls inside the stated range.
By their numbers in this assay, from the lowest: compound 1; then compound 3; then compound 2.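

In this assay, the step from butyl to isobutyl keeps the same atoms and only joins them differently, yet it gives a 3.8-fold lower number from compound 2 to compound 3 (0.58 log units; beyond the scatter), so on this aromatic carbon the branching of the chain shifts the read-out and not just the size of the group. Isobutyl does not fully recover what isopropyl gives, as the listing of a 3.6-fold higher number from compound 1 to compound 3 (0.56 log units; beyond the scatter) shows, which places the branched four-carbon chain as an intermediate, with both of its steps beyond the usual scatter. Nothing available here accounts for either step, so the reason for this order remains unexplained.

All three groups at this place are plain saturated carbon chains on the same core, so these compounds cannot tell whether a more compact branched group such as tert-butyl would continue the order or whether a longer chain such as hexyl would raise the number further. They also leave open how a group of another kind on this aromatic carbon, such as an amine or a carboxylic acid, would compare with isopropyl.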